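The source may hold more compounds than are shown below. What is called first, only, known or untested is meant among the compounds shown, and "the series" means these compounds.

Among the measured compounds shown here, compound 3 `CSc1cc(C(=O)N2CCc3ccccc32)cc(C#N)c1O` is one of three compounds measured so far in an assay on tissue (RPTEC cells) for inhibition of solute carrier family 22 member 12 (Homo sapiens), read by scintillation counting, with stated times of 15 min and 2 h; a lower number here means a stronger inhibitor, a higher number a weaker inhibitor. In this assay compound 3 sits only at a limit, > 100000 nM, and no number is known for it. Compound 1 `COc1cc(C(=O)N2CCc3ccccc32)cc(C#N)c1O` likewise reaches only a limit in this assay, > 100000 nM. Compound 2 `N#Cc1cc(C(=O)N2CCc3ccccc32)cc(I)c1O` does give a number in this assay, 5300 nM. The step of an at least 18-fold lower number from compound 1 to compound 2 (1.27 log units; beyond the scatter) and the step of an at least 18-fold higher number from compound 2 to compound 3 (1.27 log units; beyond the scatter) are both large, whereas the step that the two limits leave unreadable from compound 1 to compound 3 cannot be read because of the limit of > 100000 nM in this assay, at which 2 of the 3 values shown sit. Among these three, then, only compound 2 with its iodo group shows a measurable inhibition, while compound 1 and compound 3 both remain at the limit.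

Compound 4 `CC(C)(C)c1cc(C(=O)N2CCc3ccccc32)cc(C#N)c1O` has not yet been measured. It differs from compound 3 by tert-butyl in place of methylsulfanyl on an aromatic carbon. For the measured compounds named here, the two readable steps describe the exchange of methoxy or of methylsulfanyl for iodo; tert-butyl is neither of these groups, so they bear on compound 4 only by analogy, and the three compounds give no direct precedent for it. Compound 4 is nevertheless expected to give a number in this assay, estimated at 15000 nM, within a range from 2000 nM to 100000 nM. This would correspond to an expected step of an at least 6.6-fold lower number from compound 3 to compound 4 (0.82 log units; beyond the scatter).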

Compound 4, half-maximal inhibitory concentration: 31600 nM
Estimate against measurement, compound 4: 2.1-fold (0.32 log units) below; measured number inside the range.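

Among the compounds shown here, compound 4 shows that iodo is not the only group at this position, ortho to a hydroxy group, that gives a number in this assay, and that a group with no hydrogen-bond acceptor can do so as well. Tert-butyl in place of methylsulfanyl gives an at least 3.1-fold lower number from compound 3 to compound 4 (0.50 log units; beyond the scatter), and tert-butyl in place of methoxy gives an at least 3.1-fold lower number from compound 1 to compound 4 (0.50 log units; beyond the scatter), while tert-butyl in place of iodo gives a 6.0-fold higher number from compound 2 to compound 4 (0.78 log units; beyond the scatter), so iodo keeps a modest lead over the new group. The two steps from compound 1 and compound 3 fix only a minimum size and not a true one, because the values of those two compounds are limits and not numbers: the limit of > 100000 nM in this assay, at which 2 of the 4 values shown sit.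

The compounds shown leave open how a bromo, a chloro or an isopropyl group at this same position would stand against iodo and tert-butyl. They also leave open whether a carboxylic acid or an amine here would give a number at all, and four compounds with a single point of change set no order beyond themselves.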